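Bromo for Methoxy, Carried from One Core to Another

The source may hold more compounds than are shown below. What is called first, only, known or untested is meant among the compounds shown, and "the series" means these compounds.

Of the compounds shown here, three have been measured in a functional assay on HCT-116 cells (Homo sapiens) for antiproliferative activity, read by MTT assay, with a stated time of 72 h; a lower number here means a stronger inhibitor, a higher number a weaker inhibitor. Compound 1 `CCOC(=O)c1csc2nc(CN3CCN(Cc4ccccc4)CC3)c(-c3ccc(OC)cc3)n12` gives 19600 nM, and compound 2 `CCOC(=O)c1csc2nc(CN3CCN(Cc4ccccc4)CC3)c(-c3ccc(Br)cc3)n12` gives 37200 nM. The change between them is bromo in place of methoxy on an aromatic carbon, and it made a step of a 1.9-fold higher number from compound 1 to compound 2 (0.28 log units; within the scatter). Compound 3 `COc1ccc(-c2c(CN3CCCCC3)nc3scc(C(=O)O)n23)cc1` rests on a different core; the difference between the two cores is not broken down here. In this assay compound 3 gives 84600 nM, the highest of the three numbers. Compound 4 `O=C(O)c1csc2nc(CN3CCCCC3)c(-c3ccc(Br)cc3)n12` has not yet been measured. It differs from compound 3 by bromo in place of methoxy on an aromatic carbon, the same change that was made from compound 1 to compound 2. Among the measured compounds shown here, for compound 4 a step of a 1.9-fold higher number from compound 3 to compound 4 (0.28 log units; within the scatter) is expected, because the earlier step was a 1.9-fold higher number from compound 1 to compound 2 (0.28 log units; within the scatter) and nothing among the measured compounds suggests a different outcome on the core of compound 3. Compound 4 is therefore estimated at 160000 nM, with a likely range from 60000 nM to 400000 nM.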

Compound 4, half-maximal inhibitory concentration: > 100000 nM
Compound 4 ended at the assay's limit; the forecaster's own chance of this, stated with the estimate: 30%; the middle value does not contradict the limit.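

In this assay compound 4 gives > 100000 nM, which is a limit of the assay and not a number. Bromo in place of methoxy on this second core produced an at least 1.1-fold higher number from compound 3 to compound 4 (0.07 log units; that floor lies within the scatter), so the step can be read only as a floor, and that floor alone shows no rise beyond the scatter. The result neither confirms that the change carries over with the same size nor shows that it behaves differently on the two cores: the same change on two cores in this assay, a 1.9-fold higher number (0.28 log units; within the scatter) from compound 1 to compound 2 and an at least 1.1-fold higher number (0.07 log units; that floor lies within the scatter) from compound 3 to compound 4; the limit leaves it open whether they differ

On these data alone, what a chloro or a nitrile in place of the bromo would give on either core remains open. So does the size of this change on the core of compound 3 when the value stays clear of the limit.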